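The compounds below may be only part of what the source reports. "The series", "measured", "known", "first", "only" and "open" are said of these compounds alone.

Compound 1 `CN1CCN(c2nc(-c3ccc(Cl)c(Cl)c3)nc3c2ncn3C)CC1`: 65.2%
Compound 2 `CN1CCN(c2nc(-c3ccccc3O)nc3c2ncn3C)CC1`: a limit, > 80%

In an assay on cells for displacement of a labelled ligand from adenosine receptor A1 (Homo sapiens), read by scintillation counting and radioligand binding, with a stated time of 60 min, tested at 10 uM (a higher number here means more inhibition at the concentration tested (going by the name of the read-out), a lower number less inhibition), compound 1 gives 65.2%. For compound 2 the reported figure is a limit of the assay rather than a number; compound 2 sits at the limit of > 80% in this assay, at which 1 of the 2 values shown sits. For the measured compounds named here, the single measured step, a number at least 14.8 percentage points higher from compound 1 to compound 2 (beyond the scatter), accompanied the exchange of 3,4-dichlorophenyl for 2-hydroxyphenyl, so compound 2 stands at the top of the two values shown, with only a limit to mark it.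

Compound 3 `CN1CCN(c2nc(-c3cccc(Cl)c3)nc3c2ncn3C)CC1` carries 3-chlorophenyl in place of 2-hydroxyphenyl on an aromatic carbon. This change runs opposite to the measured step: a chlorophenyl returns in place of the 2-hydroxyphenyl, here 3-chlorophenyl rather than the 3,4-dichlorophenyl of compound 1. A fall beyond the scatter is therefore expected, with a step of a number at least 15 percentage points lower from compound 2 to compound 3 (beyond the scatter) in this assay for compound 3. Compound 3 is estimated at 65%, expected to lie between 42% and 82%.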

Compound 3, a percentage reported as inhibition, at one concentration (the size of the read-out at that concentration, not a potency): 45.7%
For compound 3 the middle estimate is 19.3 percentage points above the measured one, within the range that was stated.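

In this assay the number of chlorines does not by itself order the aryl groups at this position. Taking one chloro away from the 3,4-dichlorophenyl goes with a number 19.5 percentage points lower from compound 1 to compound 3 (beyond the scatter), yet compound 2, which carries no chlorine, stands highest of the three, and the exchange of its 2-hydroxyphenyl for 3-chlorophenyl brings a number at least 34.3 percentage points lower from compound 2 to compound 3 (beyond the scatter), a large step. The figure for compound 2 is a limit and not a number: the limit of > 80% in this assay, at which 1 of the 3 values shown sits.

The compounds shown leave open whether the high value of compound 2 belongs to the hydroxyl itself or to where it sits on the phenyl ring. An unsubstituted phenyl, a 3-hydroxyphenyl or a 2-methoxyphenyl group at this position would bear on that question.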